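Swapping the five-membered ring for pyrimidine on the shared core

The compounds below may be only part of what the source reports. "The series", "measured", "known", "first", "only" and "open" are said of these compounds alone.

Measured so far, in an ADME assay on cells for inhibition of cytochrome P450 11B1, mitochondrial (Homo sapiens), read by HPLC, with a stated time of 60 min; a higher number here means a weaker inhibitor, a lower number a stronger inhibitor:
Compound 1, `Fc1ccc2nc(-c3cn[nH]c3)n(C3CC3)c2c1`, gives 1670 nM.
Compound 2, `Fc1ccc2nc(-c3cncs3)n(C3CC3)c2c1`, gives 4520 nM.

Among the two measured compounds, compound 2 has the highest number, and its nearest neighbour is compound 1 at a lower value; the one measured step, a 2.7-fold higher number from compound 1 to compound 2 (0.43 log units; beyond the scatter), is modest but beyond the usual scatter, so compound 2 is the weaker inhibitor of the pair.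

Compound 3, `Fc1ccc2nc(-c3cncnc3)n(C3CC3)c2c1`, differs from compound 2 in one place: pyrimidin-5-yl in place of 1,3-thiazol-5-yl on an aromatic carbon. The ring sits on an aromatic carbon of the shared core, between two ring nitrogen atoms and next to the ring atom that bears the cyclopropyl group.

Among the measured compounds shown here, only the step from compound 1 to compound 2 bears on this change, and it compared two five-membered rings; no measured step shows what a six-membered ring with two nitrogen atoms does at this position. The expected step of a 1.1-fold higher number from compound 2 to compound 3 (0.04 log units; within the scatter) is therefore set at about no change beyond the scatter, with a wide range. Compound 3 is estimated at 5000 nM in this assay, between 1700 nM and 15000 nM.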

Compound 3, half-maximal inhibitory concentration: 5380 nM
The estimate for compound 3 lay 1.1-fold (0.03 log units) below the measured number; measured number inside the range.
By their numbers in this assay, from the lowest: compound 1; then compounds 2 and 3 (each within the scatter of the next).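

In this assay, pyrimidin-5-yl in place of 1,3-thiazol-5-yl on this aromatic carbon gives a 1.2-fold higher number from compound 2 to compound 3 (0.08 log units; within the scatter), so at this position a six-membered aromatic ring and this five-membered one cannot be told apart. Set against 1H-pyrazol-4-yl, the same pyrimidin-5-yl gives a 3.2-fold higher number from compound 1 to compound 3 (0.51 log units; beyond the scatter), which leaves compound 1 as the strongest inhibitor of the three and shows that ring size alone does not sort these compounds, since compound 1 and compound 2 both carry five-membered rings yet are separated by a 2.7-fold higher number from compound 1 to compound 2 (0.43 log units; beyond the scatter). Nothing measured here accounts for why the 1H-pyrazol-4-yl compound stands apart from the other two.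

From the compounds shown here alone, it remains open whether a plain phenyl ring at this position would fall with compound 2 and compound 3 or nearer to compound 1. Also open, going by these compounds, is how the number would respond to an amine or a carboxylic acid on the ring at this position, or to a longer chain in place of the cyclopropyl group.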